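A nitro group added to compound 2

The source may hold more compounds than are shown below. What is called first, only, known or untested is meant among the compounds shown, and "the series" means these compounds.

Compound 1 `COc1ccc(C2CC(Nc3nc4ccc([N+](=O)[O-])cc4s3)=NN2C(C)=O)cc1O` with 178 umol/kg
Compound 2 `CC(=O)N1N=C(Nc2nc3ccccc3s2)CC1c1ccc(Cl)cc1` with 209 umol/kg

In a functional assay on the whole organism (Hindlimb, strain albino) with Mus musculus as the target, in the maximal electroshock model, with a stated time of 0.5 h (a lower number here means that less compound is needed, a higher number that more compound is needed for the effect), compound 2 stands at 209 umol/kg, level within the scatter with compound 1 at 178 umol/kg. Compound 3 `CC(=O)N1N=C(Nc2nc3ccc([N+](=O)[O-])cc3s2)CC1c1ccc(Cl)cc1` follows from compound 2 through one structural change, nitro in place of hydrogen on an aromatic carbon. Among the compounds with values here, no measured step isolates this change, so the size of its effect cannot be read from the data, and no step beyond the scatter is expected in this assay. The expected result is a 1.1-fold lower number from compound 2 to compound 3 (0.04 log units; within the scatter). The estimate for compound 3 is 190 umol/kg, with an expected range from 85 umol/kg to 420 umol/kg.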

Compound 3, dose for half-maximal effect: 132 umol/kg
Beside the measured number, compound 3's estimate is 1.4-fold (0.16 log units) above it; low and high end bracket the measured number.
By their numbers in this assay, from the lowest: compounds 3, 1 and 2 (each within the scatter of the next).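

In this assay, nitro in place of hydrogen on an aromatic carbon gives a 1.6-fold lower number from compound 2 to compound 3 (0.20 log units; within the scatter), so this position carries the added group with no step beyond the scatter. With the nitro group in place on both compounds, 4-chlorophenyl in place of 3-hydroxy-4-methoxyphenyl on a saturated ring carbon gives a 1.3-fold lower number from compound 1 to compound 3 (0.13 log units; within the scatter), which is also no step beyond the scatter. No measurement at hand offers an explanation for either result. Going by these compounds, whether an amine or a carboxylic acid at this aromatic carbon would give a step beyond the scatter remains open.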